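Replacing the benzyl group at the core of compound 1

The source may hold more compounds than are shown below. What is called first, only, known or untested is meant among the compounds shown, and "the series" means these compounds.

Measured compounds:
compound 1 `Fc1ccc(Cc2ccc3c(NCCCNCc4ccco4)ccnc3c2)c(Cl)c1`: 5730 nM
compound 2 `COc1ccc(F)cc1CNCCCNc1ccnc2cc(Cc3ccc(F)cc3Cl)ccc12`: 2460 nM
compound 3 `COc1cccc(CNCCCNc2ccnc3cc(Cc4ccc(F)cc4Cl)ccc23)c1O`: 2350 nM

In an ADME assay on HepG2 cells (Homo sapiens) for cytotoxicity, read by luminescence, CellTiter-Glo and ATP content, with a stated time of 72 h (a lower number here means that less compound is needed, a higher number that more compound is needed for the effect), compound 1 gives the highest of the three numbers. Its nearest neighbour is compound 2, reached by a 2.3-fold lower number from compound 1 to compound 2 (0.37 log units; beyond the scatter), and the furthest is compound 3, reached by a 2.4-fold lower number from compound 1 to compound 3 (0.39 log units; beyond the scatter); between those two lies a 1.0-fold lower number from compound 2 to compound 3 (0.02 log units; within the scatter). All three steps change the group on the saturated chain carbon bound to the amine nitrogen, not the core.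

Compound 4 `CCC(CC)c1ccc2c(NCCCNCc3ccco3)ccnc2c1` differs from compound 1 at another place: pentan-3-yl in place of 2-chloro-4-fluorobenzyl on an aromatic carbon. Within the data shown here, no measured step touches this aromatic carbon, so none bears on the change. The expected step of a 1.4-fold higher number from compound 1 to compound 4 (0.14 log units; within the scatter) is therefore set near nothing beyond the scatter, with a wide range. Compound 4 is estimated at 8000 nM in this assay, between 2500 nM and 25000 nM.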

Compound 4, half-maximal effective concentration: 6760 nM
The estimate for compound 4 lay 1.2-fold (0.07 log units) above the measured number; measured number inside the range.
By their numbers in this assay, from the lowest: compounds 3 and 2 (each within the scatter of the next); then compounds 1 and 4 (each within the scatter of the next).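

In this assay, the aromatic carbon that carries the 2-chloro-4-fluorobenzyl group accepts pentan-3-yl, a group with no ring, and the exchange gives a 1.2-fold higher number from compound 1 to compound 4 (0.07 log units; within the scatter). Among these compounds, the number therefore does not depend on keeping that benzyl group, whereas the earlier steps beyond the scatter all changed the group on the saturated chain carbon. No measurement here explains this result. On these data alone, it remains open whether a methyl group, an amine or a carboxylic acid on this carbon would also hold the number. Also open, as far as these compounds go, is whether pentan-3-yl behaves alike with the 5-fluoro-2-methoxyphenyl group on the chain.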